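The source may hold more compounds than are shown below. What is called first, only, known or untested is meant among the compounds shown, and "the series" means these compounds.

Of the compounds shown here, two built on a shared core have been measured in an assay on CHO cells for agonist activity at Free fatty acid receptor 1 (Homo sapiens), read by FLIPR; a higher number here means that more compound is needed for the effect, a lower number that less compound is needed. Compound 1 `Cc1nc(-c2ccc(C(F)(F)F)cc2)sc1COc1ccc(OCC(=O)O)c(F)c1` gives 149 nM. Compound 2 `Cc1nc(-c2cccc(F)c2)sc1COc1ccc(OCC(=O)O)c(F)c1` gives 185 nM. Going by the values given here, the only measured step, a 1.2-fold higher number from compound 1 to compound 2 (0.09 log units; within the scatter), exchanges the whole aryl group on the core, and it is too small to separate the two compounds. Compound 2 thus holds the higher of the two numbers on paper, but its gap to compound 1 lies within the scatter, so nothing can be said about which of them needs less compound.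

Compound 3 `Cc1cccc(-c2nc(C)c(COc3ccc(OCC(=O)O)c(F)c3)s2)c1` is yet to be measured. It differs from compound 2 in one place: methyl in place of fluoro on an aromatic carbon. Among the compounds with values here, no measured step alters a single substituent on that ring, so the one step that exists bears on the question only loosely; it was itself within the scatter, which gives no reason to expect a large movement here. The expectation for compound 3 is therefore a number close to that of compound 2, a 1.1-fold higher number from compound 2 to compound 3 (0.03 log units; within the scatter), with an estimate of 200 nM and a range from 80 nM to 500 nM.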

Compound 3, half-maximal effective concentration: 247 nM
For compound 3 the middle estimate is 1.2-fold (0.09 log units) below the measured one, within the range that was stated.
By their numbers in this assay, from the lowest: compounds 1, 2 and 3 (each within the scatter of the next).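

In this assay, the exchange of a single atom on the aromatic carbon meta to a large group gives a 1.3-fold higher number from compound 2 to compound 3 (0.13 log units; within the scatter) and thus does not separate fluoro from methyl at this position. Going by these compounds alone, this is the first measured step that alters just one substituent on that ring, so it is a cleaner test of this position than the exchange of the whole aryl group in the earlier pair. The broader exchange, which replaces 4-(trifluoromethyl)phenyl with 3-methylphenyl, gives a 1.7-fold higher number from compound 1 to compound 3 (0.22 log units; within the scatter) and so also fails to separate the two compounds, leaving the three aryl groups on the shared core indistinguishable in this measurement. No experimental evidence is available to explain why these groups give such similar numbers.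

The compounds shown leave open whether an amine or a hydroxyl group on this same aromatic carbon would shift the number beyond the scatter. They also leave open whether a longer chain, such as propyl, or a larger group, such as phenyl, would be tolerated there.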